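A Second Nitrooxy Chain on Compound 3

A few compounds are considered here, and "the series" means these few. Any claim that something is new, unique, unknown or untested is made for them only; others in the source may bear on it.

Going by the values given here, in a functional assay on H266 cells (Homo sapiens) for cytotoxicity, read by resazurin assay, with a stated time of 72 h (on this read-out higher numbers stand for weaker inhibition and lower numbers for stronger inhibition), compound 3 `COc1cc(/C=C/C(=O)OCCCCCO[N+](=O)[O-])ccc1O` gives 21200 nM, the only true number so far. Compound 1 `COc1cc(/C=C/C(=O)OCCCCCCO[N+](=O)[O-])ccc1O` reaches only a limit of the assay, > 50000 nM. Compound 2 `O=C(/C=C/c1ccc(OCCCCCO[N+](=O)[O-])c(O)c1)OCCCCCO[N+](=O)[O-]` also reaches only a limit, > 50000 nM. Together these two sit at the limit of > 50000 nM in this assay, at which 2 of the 3 values shown sit, so compound 3 can be placed against them only loosely.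

The next structure is compound 4 `COc1cc(/C=C/C(=O)OCCCCCO[N+](=O)[O-])ccc1OCCCCCO[N+](=O)[O-]`. It differs from compound 3 by 5-(nitrooxy)pentyl in place of hydrogen on an oxygen on an aromatic ring, with 5-(nitrooxy)pentyl in place of hydrogen on an oxygen on an aromatic ring. The hydroxy group thus becomes (5-(nitrooxy)pentyl)oxy.

Among the compounds with values here, the one measured step is an at least 2.3-fold lower number from compound 1 to compound 3 (0.37 log units; beyond the scatter), with nitrooxy in place of (nitrooxy)methyl on a saturated chain carbon. That change lies in the chain next to the carbonyl side of the molecule, not on the aromatic oxygen, so it bears on the new change only weakly. The closer guide is compound 2, which also carries 5-(nitrooxy)pentyl on an oxygen on an aromatic ring and shows the limit of > 50000 nM.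

The expected change is therefore modest and towards weaker inhibition, estimated as a 1.8-fold higher number from compound 3 to compound 4 (0.25 log units; within the scatter). For compound 4 the estimated value is 38000 nM, within an expected range from 14000 nM to 60000 nM.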

Compound 4, half-maximal inhibitory concentration: > 50000 nM
Compound 4 ended at the assay's limit (the forecaster's own chance of this, stated with the estimate: 55%); middle value at least 1.3-fold (0.11 log units) from the limit.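

In this assay, replacing the hydrogen on the aromatic oxygen of compound 3 with 5-(nitrooxy)pentyl gives an at least 2.3-fold higher number from compound 3 to compound 4 (0.37 log units; beyond the scatter), so this change weakens inhibition by more than the usual scatter. Going by these compounds alone, this is the first step at this oxygen that can be read: the earlier step, from compound 1 to compound 3, concerned the chain on the carbonyl side, and compound 2 carries the same group on the oxygen but had no partner that differed from it in this one place. The value of compound 4 is a limit of the assay and not a true number, so only a minimum size is known for the step, and compound 4 joins the others at the same ceiling: the limit of > 50000 nM in this assay, at which 3 of the 4 values shown sit.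

The step between compound 2 and compound 4 cannot be read, as both values are limits. The compounds shown also leave open whether the weakening follows from losing the hydroxy hydrogen or from the chain that arrives, a question that a short ethyl group on this oxygen, or a pentyl chain ending in a carboxylic acid instead of nitrooxy, could help to separate.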